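The compounds below may be only part of what the source reports. "The series", "measured", "known", "first", "only" and "open" are said of these compounds alone.

Compound 1 `CN1CCN(c2ccc(Nc3ncc4c(n3)N(C3CCCC3)CC(=O)N4C)nc2)CC1`: 13100 nM
Compound 2 `CN1C(=O)CN(C2CCCC2)c2nc(Nc3ccc(N4CCCCC4)cn3)ncc21`: > 30000 nM (a limit of the assay)
Compound 3 `CC1CCN(c2ccc(Nc3ncc4c(n3)N(C3CCCC3)CC(=O)N4C)nc2)CC1`: > 30000 nM (a limit of the assay)

Measured in a functional assay on HeLa cells (Homo sapiens) for inhibition, read by MTT assay, with a stated time of 48 h (on this read-out higher numbers stand for weaker inhibition and lower numbers for stronger inhibition), compound 1 gives 13100 nM. For compound 2 the value is a limit, > 30000 nM. For compound 3 the value is likewise a limit, > 30000 nM, which is the limit of > 30000 nM in this assay, at which 2 of the 3 values shown sit. Compound 3 therefore stands at the limit with no number of its own. Compound 4 `CCN1C(=O)CN(C2CCCC2)c2nc(Nc3ccc(N4CCC(C)CC4)cn3)ncc21` differs from it by methyl in place of hydrogen on a saturated chain carbon bound to an amide-type nitrogen in a ring; cut one bond further out, the change reads methyl to ethyl. Neither an at least 2.2-fold higher number from compound 1 to compound 2 (0.35 log units; beyond the scatter) nor an at least 2.2-fold higher number from compound 1 to compound 3 (0.35 log units; beyond the scatter) touches this position, and a step that the two limits leave unreadable from compound 2 to compound 3 gives no readable size. The step that the limit leaves unreadable from compound 3 to compound 4 is thus expected to lie within the scatter, leaving compound 4 at the limit. Compound 4 is estimated at 40000 nM, between 15000 nM and 100000 nM.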

Compound 4, half-maximal inhibitory concentration: > 30000 nM
Compound 4: a limit, no number; the forecaster's own chance of this, stated with the estimate: 80%; the middle value does not contradict the limit.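

For the compounds shown here, compound 3 and compound 4 each carry only a limit, so no step between them can be read: the limit of > 30000 nM in this assay, at which 3 of the 4 values shown sit. The compounds shown leave open what the change from methyl to ethyl does to inhibition where a compound gives a number rather than a limit.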